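The compounds below may be only part of what the source reports. "The series", "measured", "known", "first", "only" and "open" are said of these compounds alone.

Compound 1: `O=C(Nc1cccc(-c2ccc(F)cc2)c1)C(Cl)Cl`, 7840 nM
Compound 2: `CSc1cccc(-c2cc(NC(=O)C(Cl)Cl)cc(-c3cccc(SC)c3)c2)c1`, 15900 nM
Compound 3: `COc1ccc(-c2cc(NC(=O)C(Cl)Cl)cc(-c3ccc(OC)c(F)c3)c2)cc1F`, 1950 nM

All three compounds were tested in a functional assay on A549 cells (Homo sapiens) for cytotoxicity, read by MTT assay, with a stated time of 68 h; on this read-out higher numbers stand for weaker inhibition and lower numbers for stronger inhibition. Within that set compound 1 stands second highest of the three numbers; its nearest neighbour is compound 2, which gives a higher number, and the furthest is compound 3, which gives a lower number, and both of these gaps lie beyond the usual scatter. Compound 4, `COc1ccc(-c2cccc(NC(=O)C(Cl)Cl)c2)cc1`, has not yet been measured. It differs from compound 1 in a single place: methoxy in place of fluoro on an aromatic carbon. Within the data shown here, no pair of the measured compounds differs in just this way, so there is no measured step to lean on directly. On what the three numbers show, the change from compound 1 to compound 4 is expected to produce in this assay either no step beyond the scatter or a modest move toward a lower number. Compound 4 is accordingly estimated at 6000 nM, with a range from 2000 nM to 18000 nM. That estimate means an expected step of a 1.3-fold lower number from compound 1 to compound 4 (0.12 log units; within the scatter) in this assay.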

Compound 4, half-maximal inhibitory concentration: 8530 nM
The estimate for compound 4 lay 1.4-fold (0.15 log units) below the measured number, within the range that was stated.
By their numbers in this assay, from the lowest: compound 3; then compounds 1, 4 and 2 (each within the scatter of the next, the first and the last beyond it).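

In this assay, among these compounds, the step of a 1.1-fold higher number from compound 1 to compound 4 (0.04 log units; within the scatter) gives the first direct reading of a single exchange at this position, since no earlier pair of compounds differed in only one place. It shows that methoxy in place of fluoro, on an aromatic carbon para to a large group, does not move the number beyond the scatter, even though methoxy counts as a hydrogen-bond acceptor and fluoro does not. No measurement shown here accounts for this result.

From the compounds shown here alone, whether an amine or a carboxylic acid at the same place would also stay within the scatter remains open. Also open, going by these compounds, is what sets compound 3 apart from compound 1 and compound 4, as it differs from each in more than one place.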